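Removing Two Fluorines from a Sulfonyl Phenyl Ring

A few compounds are considered here, and "the series" means these few. Any claim that something is new, unique, unknown or untested is made for them only; others in the source may bear on it.

Measured compounds in an assay for inhibition of Nicotinamide phosphoribosyltransferase (Homo sapiens), read by mass spectrometry, with stated times of 15 min and 30 min; on this read-out higher numbers stand for weaker inhibition and lower numbers for stronger inhibition:
compound 1, `O=C(NCc1ccc(S(=O)(=O)c2ccccc2)cc1)c1nc2ccncc2s1`, gives 210 nM
compound 2, `O=C(NCc1ccc(S(=O)(=O)c2ccccc2)cc1)c1ccc2nccn2c1`, gives 18 nM
compound 3, `O=C(NCc1ccc(S(=O)(=O)c2cc(F)cc(F)c2)cc1)c1cnc2nccn2c1`, gives 2 nM

Compound 3 stands lowest of the three numbers, meaning the strongest inhibition seen so far; compound 2 is its nearest neighbour and compound 1 lies furthest away, both beyond the scatter. Compound 4, `O=C(NCc1ccc(S(=O)(=O)c2ccccc2)cc1)c1cnc2nccn2c1`, differs from compound 3 in one place: phenyl in place of 3,5-difluorophenyl on a sulfonyl sulfur. Within the data shown here, the only measured single step, a 12-fold lower number from compound 1 to compound 2 (1.07 log units; beyond the scatter), concerns an exchange of the whole core on the carbonyl carbon and says nothing about fluorines on the sulfonyl phenyl ring. Compound 2 and compound 3 differ both in core and in that ring, so their values cannot separate the two effects. Among the measured compounds shown here, no measured step therefore bears directly on the change from compound 3 to compound 4. With nothing to guide the direction, a modest weakening is expected, so compound 4 is estimated to give 5 nM in this assay, within a range from 2 nM to 15 nM, which corresponds to an expected step of a 2.5-fold higher number from compound 3 to compound 4 (0.40 log units; beyond the scatter).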

Compound 4, half-maximal inhibitory concentration: 2 nM
Compound 4: the middle estimate sits 2.5-fold (0.40 log units) above what was measured; low and high end bracket the measured number.
By their numbers in this assay, from the lowest: compounds 3 and 4 (each within the scatter of the next); then compound 2; then compound 1.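

In this assay, phenyl in place of 3,5-difluorophenyl on a sulfonyl sulfur gives no change at the digits printed from compound 3 to compound 4 (within the scatter), so on this core the low number does not depend on the two fluorines. Among these compounds, compound 4 also supplies what the earlier compounds lacked, a comparison in which the sulfonyl phenyl stays the same and only the group on the carbonyl carbon differs: there is a 9.0-fold lower number from compound 2 to compound 4 (0.95 log units; beyond the scatter), and there is a 110-fold lower number from compound 1 to compound 4 (2.02 log units; beyond the scatter), so in these two pairs the core alone is tied to a clear difference in the number, while the fluorine exchange shows none. No separate measurement is available to explain either the absence of a fluorine effect or the differences between the cores.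

The compounds shown leave open whether the fluorines would also make no difference on the cores of compound 1 and compound 2, since the 3,5-difluorophenyl group appears here on only one core. They also leave open how far this place on the sulfonyl sulfur tolerates other groups, such as a phenyl ring carrying a methoxy group, an amine or a carboxylic acid, or a pyridine ring in place of phenyl.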